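This account rests on a few compounds, and the source may have more. Where it says the series, first, only, none or still open, it means among the compounds named here.

Measured in a functional assay on the whole organism for agonist activity, with Mus musculus as the target; a higher number here means that more compound is needed for the effect, a lower number that less compound is needed:
- compound 1 `CC(=O)N(C)CC#CCN1CCCC1` gives 0.55 mg/kg
- compound 2 `COC(=O)N(C)CC#CCN1CCCC1` gives 5.5 mg/kg
- compound 3 `COC(=O)N(C)CC#CCn1ccnc1` gives 4.5 mg/kg

Compound 2 stands at the high-number end of this short series. Among the compounds with values here, two measured steps touch it: a 1.2-fold lower number from compound 2 to compound 3 (0.09 log units; within the scatter) is small, while a 10-fold higher number from compound 1 to compound 2 (1.00 log units; beyond the scatter) is large, with methoxy in place of methyl on a carbonyl carbon. Compound 4 `COC(=O)N(C)C(C)C#CCN1CCCC1` differs from compound 2 by methyl in place of hydrogen on a saturated chain carbon bound to an amide-type nitrogen and a triple-bonded carbon and so carries methyl in place of hydrogen on a saturated chain carbon bound to an amide-type nitrogen and a triple-bonded carbon. Neither measured step changes that carbon, so they show only how far a single change can move the number and give no firm direction. A cautious expectation in this assay is a modest rise, and the estimated change is a 2.0-fold higher number from compound 2 to compound 4 (0.30 log units; within the scatter) with wide uncertainty. For compound 4 the expected value is 11 mg/kg with an estimated range from 3 mg/kg to 40 mg/kg as its likely span.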

Compound 4, dose for half-maximal effect: 14.2 mg/kg
Beside the measured number, compound 4's estimate is 1.3-fold (0.11 log units) below it, and the stated range covers the measured number.
By their numbers in this assay, from the lowest: compound 1; then compounds 3 and 2 (each within the scatter of the next); then compound 4.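

In this assay, the saturated chain carbon bound to an amide-type nitrogen and a triple-bonded carbon turns out to affect the number: methyl in place of hydrogen there gives a 2.6-fold higher number from compound 2 to compound 4 (0.41 log units; beyond the scatter). The earlier steps shown here left the direction of a change at this carbon unknown, and this one points towards more compound being needed. Nothing available explains this rise.

Going by these compounds, whether ethyl or a longer chain on that carbon would move the number further remains open. So does whether the same methyl would act alike in compound 1 or compound 3.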